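Stretching the Amine Chain Further

This account rests on a few compounds, and the source may have more. Where it says the series, first, only, none or still open, it means among the compounds named here.

In a functional assay on L1210 cells (Mus musculus) for inhibition, with a stated time of 96 h (a higher number here means a weaker inhibitor, a lower number a stronger inhibitor), compound 1 `CCCNCCCCNCCCNCCC` gives 33000 nM, while compound 2 `CCCNCCCCCNCCCCNCCC` gives 1200 nM, the lower of the two numbers. Compound 3 `CCCNCCCCCNCCCCCNCCC` differs from compound 2 as follows: (propylamino)methyl in place of propylamino on a saturated chain carbon, four bonds along the chain from an amine nitrogen. Among the measured compounds shown here, the one measured step that bears on this is the large 28-fold lower number from compound 1 to compound 2 (1.44 log units; beyond the scatter), which also lengthened the chain. For the measured compounds named here, the change here is shorter, and only that one step supports a trend, so in this assay a smaller step toward a lower number is expected, perhaps none beyond the scatter. For compound 3 the estimated value is 700 nM, within a range of 150 nM to 3000 nM. This estimate means an expected 1.7-fold lower number from compound 2 to compound 3 (0.23 log units; within the scatter).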

Compound 3, half-maximal inhibitory concentration: 6000 nM
Beside the measured number, compound 3's estimate is 8.6-fold (0.93 log units) below it, and the stated range ends below it.
By their numbers in this assay, from the lowest: compound 2; then compound 3; then compound 1.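

In this assay, a longer chain does not keep giving a stronger inhibitor: with (propylamino)methyl in place of propylamino, four bonds along the chain from an amine nitrogen, there is a 5.0-fold higher number from compound 2 to compound 3 (0.70 log units; beyond the scatter) in the weaker direction. The earlier change ran the other way, with a 28-fold lower number from compound 1 to compound 2 (1.44 log units; beyond the scatter) toward a stronger inhibitor. Among these compounds, then, chain length has a favourable limit, and compound 2 sits nearest it. Nothing measured here explains the reversal. Still open, going by these compounds, is whether an even longer chain would weaken inhibition further, and whether a hydroxyl group or an ether oxygen on this chain would change the outcome.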